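Cytotoxicity in the shared core: from fluorobenzyl to phenylpropyl sulfide

This account rests on a few compounds, and the source may have more. Where it says the series, first, only, none or still open, it means among the compounds named here.

Three compounds on the shared core have been run in a toxicity assay on GES1 cells (Homo sapiens) for inhibition, read by MTT assay, with a stated time of 72 h; a lower number here means a stronger inhibitor, a higher number a weaker inhibitor. Compound 1 `Cc1cc(N2CC[C@@H](C)[C@@H](N(C)c3ncnc4[nH]ccc34)C2)n2nc(SCc3ccc(Cl)cc3)nc2n1` gives only the assay limit, > 100000 nM. Compound 3 `Cc1cc(N2CC[C@@H](C)[C@@H](N(C)c3ncnc4[nH]ccc34)C2)n2nc(SCc3ccc(F)c(Cl)c3)nc2n1` likewise returns only the limit, > 100000 nM. Within the data shown here, compound 2 `Cc1cc(N2CC[C@@H](C)[C@@H](N(C)c3ncnc4[nH]ccc34)C2)n2nc(SCc3ccc(F)cc3)nc2n1` gives 12300 nM in this assay, the one measurable number in the set; the other two sit at the limit of > 100000 nM in this assay, at which 2 of the 3 values shown sit.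

The measured steps run in both directions around compound 2: an at least 8.1-fold lower number from compound 1 to compound 2 (0.91 log units; beyond the scatter), and an at least 8.1-fold higher number from compound 2 to compound 3 (0.91 log units; beyond the scatter). Among the measured compounds shown here, both concern a halogen on the aromatic ring of the benzyl group, and both show that compound 2 is the only member giving a readable number.

Compound 4 `Cc1cc(N2CC[C@@H](C)[C@@H](N(C)c3ncnc4[nH]ccc34)C2)n2nc(SCCCc3ccccc3)nc2n1` changes compound 2 differently: phenethyl in place of 4-fluorophenyl on a saturated chain carbon bound to a sulfur. For the measured compounds named here, no measured step replaces the ring's fluorine with hydrogen or lengthens the chain, so neither step above bears directly on it. Going by the values given here, since compound 2 is the sole numeric value and its neighbours sit at the limit, compound 4 is expected to move back toward weaker inhibition, with a 3.3-fold higher number from compound 2 to compound 4 (0.51 log units; beyond the scatter) as the estimated step. For compound 4 the estimated value in this assay is 40000 nM, expected between 8000 nM and 100000 nM.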

Compound 4, half-maximal inhibitory concentration: > 100000 nM
Compound 4: a limit, no number; the forecaster's own chance of this, stated with the estimate: 50%; at least 2.5-fold (0.39 log units) between middle value and limit.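

In this assay, going from (4-fluorobenzyl)sulfanyl to (3-phenylpropyl)sulfanyl gives an at least 8.1-fold higher number from compound 2 to compound 4 (0.91 log units; beyond the scatter), and the result for compound 4 is a limit of the assay, not a number. The earlier steps shown here changed only the halogens on the aromatic ring of the benzyl group, whereas this one changes the chain and removes the ring fluorine, and it still ends at the limit. The steps from compound 1 and from compound 3 to compound 4 cannot be read, as both ends of each are limits, and compound 2 remains the only member with a number: the limit of > 100000 nM in this assay, at which 3 of the 4 values shown sit.

Compound 4 differs from compound 2 in both chain length and ring fluorine, so the step does not show which of the two changes matters; a plain benzyl group or a 3-(4-fluorophenyl)propyl group would separate them. Also open, on these data alone, is whether an amine or a carboxylic acid on the chain would give a readable number in this assay.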